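The source may hold more compounds than are shown below. What is called first, only, known or untested is meant among the compounds shown, and "the series" means these compounds.

Of the compounds shown here, three have been tested in an ADME assay on BJ cells (Homo sapiens) for cytotoxicity, with a stated time of 72 h (a lower number here means that less compound is needed, a higher number that more compound is needed for the effect), and none of them has yet given a number. Compound 1 `Nc1nc(-c2ccccn2)nn1-c1ncnc2ccccc12` gives > 50000 nM, which is a limit of the assay. Compound 2 `COc1cc2c(-n3nc(-c4ccccn4)nc3N)ncnc2cc1OCc1ccccc1`, which keeps the shared core and carries further groups on it, gives > 27000 nM, again a limit. Compound 3 `COc1cc2ncnc(-n3nc(-c4ccccn4)nc3N)c2cc1OCCCNC(=O)CN1C[C@@H](C)O[C@@H](C)C1` gives > 25000 nM, also a limit. Compound 3 therefore stands where the other two stand, with a limit and no number of its own.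

Compound 4 `COc1cc2ncnc(-n3nc(-c4ccccn4)nc3N)c2cc1OCCCNC(=O)OCC(F)(F)F` departs from compound 3 at a single place: it has 2,2,2-trifluoroethoxy in place of (2,6-dimethylmorpholin-4-yl)methyl on a carbonyl carbon. For the measured compounds named here, no pair of tested compounds differs in one place only, so the data hold no measured step to serve as a guide. All three readings in this assay are limits, and that is the only ground for an expectation here. No step beyond the usual scatter is expected, and neither direction is favoured. The expected change is a step that the limit leaves unreadable from compound 3 to compound 4, an estimate and no more. Compound 4 may well be reported as a limit too. For compound 4 the estimated value is 30000 nM, with an expected range from 12000 nM to 60000 nM.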

Compound 4, half-maximal effective concentration: > 11000 nM
Compound 4: no number, only a limit (the forecaster's own chance of this, stated with the estimate: 75%); the middle value does not contradict the limit.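

For the compounds shown here, compound 3 and compound 4 both carry only limits and no number, so no step between them can be read. The compounds shown leave open at what concentration any of the four reaches its half-maximal effect, and whether 2,2,2-trifluoroethoxy in place of (2,6-dimethylmorpholin-4-yl)methyl on a carbonyl carbon changes the reading at all.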